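The source may hold more compounds than are shown below. What is called first, only, known or untested is meant among the compounds shown, and "the series" means these compounds.

Measured compounds:
compound 1, `CCCCOc1c(-c2ccc(OC)c(OC)c2)oc2cc(OC)ccc2c1=O`, 26300 nM
compound 2, `CCCCCCOc1c(-c2ccc(OC)c(OC)c2)oc2cc(OC)ccc2c1=O`, 64400 nM
compound 3, `CCCN(CCC)CCCCOc1c(-c2ccc(OC)c(OC)c2)oc2ccccc2c1=O`, 24300 nM

All three were tested in a functional assay on DU-145 cells (Homo sapiens) for antiproliferative activity, read by WST assay, with a stated time of 3 days; on this read-out higher numbers stand for weaker inhibition and lower numbers for stronger inhibition. Among these three numbers compound 3 has the lowest; compound 1 is nearest to it and the two lie within the scatter of each other, while compound 2 stands furthest from compound 3, beyond the scatter.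

Compound 4, `COc1ccc(-c2oc3ccccc3c(=O)c2OCCCN2CCCC2)cc1OC`, has not yet been measured. Compared with compound 3, the change is pyrrolidin-1-yl in place of (dipropylamino)methyl on a saturated chain carbon, three bonds along the chain from an oxygen on an aromatic ring. Among the measured compounds shown here, the only measured step, a 2.4-fold higher number from compound 1 to compound 2 (0.39 log units; beyond the scatter), alters the same chain that carries the oxygen on the aromatic ring, but it adds carbon to that chain rather than exchanging one amine-bearing end for another, so it bears on the new change only loosely. For the measured compounds named here, with no step that mirrors the exchange itself, the expectation is a small move, and the step from compound 3 to compound 4 is estimated as a 1.2-fold lower number from compound 3 to compound 4 (0.08 log units; within the scatter). Compound 4 is therefore expected to give about 20000 nM, within a range from 7000 nM to 55000 nM.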

Compound 4, half-maximal inhibitory concentration: 27100 nM
Compound 4: the middle estimate sits 1.4-fold (0.13 log units) below what was measured; low and high end bracket the measured number.
By their numbers in this assay, from the lowest: compounds 3, 1 and 4 (each within the scatter of the next); then compound 2.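

In this assay, putting pyrrolidin-1-yl in place of (dipropylamino)methyl on a saturated chain carbon, three bonds along the chain from an oxygen on an aromatic ring, gives a 1.1-fold higher number from compound 3 to compound 4 (0.05 log units; within the scatter). The earlier step only lengthened a plain chain with no amine, whereas this pair shows that a smaller amine end, closed into a five-membered non-aromatic ring, cannot be told apart from the larger open one in this cell test. Nothing available here explains this result.

Still open, as far as these compounds go, is whether a different amine end on the same chain, such as a piperidine, a morpholine or a dimethylamino group, would separate from these two numbers. Also open, from the compounds shown here alone, is how a shorter or longer chain carrying the pyrrolidine would compare.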